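The source may hold more compounds than are shown below. What is called first, only, known or untested is meant among the compounds shown, and "the series" means these compounds.

Working notes on the series in a functional assay (trachea) with Cavia porcellus as the target; a lower number here means a stronger inhibitor, a higher number a weaker inhibitor. Compound 1 `Cn1nc(-c2cccnc2)c2ccccc2c1=O` gives 11500 nM, compound 2 `CCn1nc(-c2cccnc2)c2ccccc2c1=O` gives 1320 nM and compound 3 `CC(=O)OCCn1nc(-c2cccnc2)c2ccccc2c1=O` gives 9770 nM. The clear gain so far is an 8.7-fold lower number from compound 1 to compound 2 (0.94 log units; beyond the scatter). Compound 3 stands level with compound 1, with a 1.2-fold lower number from compound 1 to compound 3 (0.07 log units; within the scatter), and well above compound 2, with a 7.4-fold higher number from compound 2 to compound 3 (0.87 log units; beyond the scatter).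

Next is compound 4 `O=c1c2ccccc2c(-c2cccnc2)nn1CCO`, which has hydrogen in place of acetyl on an oxygen on a saturated carbon, taking 2-acetoxyethyl to 2-hydroxyethyl (hydrogen in place of acetyl on an oxygen on a saturated carbon). For the measured compounds named here, no measured step makes this change. The nearest evidence is the acetoxy step, a 7.4-fold higher number from compound 2 to compound 3 (0.87 log units; beyond the scatter), which sets the largest return that could be read from the series. Compound 4 still carries an oxygen on the chain, so only part of that return is expected in this assay, towards a lower number. The expected step is a 1.6-fold lower number from compound 3 to compound 4 (0.21 log units; within the scatter), probably no larger than the scatter. The estimate for compound 4 is 6000 nM, with an expected range of 1800 nM to 20000 nM.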

Compound 4, half-maximal inhibitory concentration: 4570 nM
Compound 4: the middle estimate sits 1.3-fold (0.12 log units) above what was measured, within the range that was stated.
By their numbers in this assay, from the lowest: compound 2; then compound 4; then compounds 3 and 1 (each within the scatter of the next).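

In this assay, the step from 2-acetoxyethyl to 2-hydroxyethyl is beyond the scatter (a 2.1-fold lower number from compound 3 to compound 4 (0.33 log units; beyond the scatter)), so the acetyl on this oxygen matters in its own right, and the acetoxy step seen earlier does not rest on the chain oxygen alone. The return is only partial, as 2-hydroxyethyl still falls short of plain ethyl (a 3.5-fold higher number from compound 2 to compound 4 (0.54 log units; beyond the scatter)), yet it now stands clear of methyl (a 2.5-fold lower number from compound 1 to compound 4 (0.40 log units; beyond the scatter)), a separation the acetoxy compound did not show. Nothing available here explains these differences.

The compounds shown leave open whether the gain from methyl to ethyl continues with a longer chain such as propyl or butyl. They also leave open how an amine or a carboxylic acid at the chain end would compare with the hydroxy group of compound 4.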